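This account rests on a few compounds, and the source may have more. Where it says the series, first, only, none or still open, it means among the compounds named here.

Compound 1, `Cc1ccccc1-c1nn(-c2ccc(F)cc2F)cc1CNCCN1CCN(C)CC1`: in an ADME assay on Huh-7 cells (Homo sapiens) for cytotoxicity (on this read-out lower numbers stand for higher toxicity in this test and higher numbers for lower toxicity in this test), compound 1 gives > 20000 nM, which is a limit of the assay.
Compound 2, `CN1CCN(CCNCc2cn(-c3ccc(F)cc3F)nc2-c2ccccc2Cl)CC1`: in this assay compound 2 gives > 20000 nM, which is a limit of the assay.
Compound 3, `CN1CCN(CCNCc2cn(-c3ccc(F)cc3F)nc2C(C)(C)C)CC1`: in this assay compound 3 gives > 20000 nM, which is a limit of the assay.

Compound 3 therefore stands where every measured compound stands, at the limit of > 20000 nM in this assay, at which 3 of the 3 values shown sit, and none of the three is separated from the others by a readable number. The step that the two limits leave unreadable from compound 1 to compound 2 and the steps a step that the two limits leave unreadable from compound 1 to compound 3 and a step that the two limits leave unreadable from compound 2 to compound 3 all fall between two limits, so their size cannot be read.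

Compound 4, `Cc1cccc(-c2nn(-c3ccc(F)cc3F)cc2CNCCN2CCN(C)CC2)c1`, differs from compound 3 by 3-methylphenyl in place of tert-butyl on an aromatic carbon. For the measured compounds named here, the steps that bear on it are those from an aryl group to tert-butyl at this carbon, a step that the two limits leave unreadable from compound 1 to compound 3 and a step that the two limits leave unreadable from compound 2 to compound 3, and both are unreadable. Going by the values given here, nothing among the measured compounds points to a step beyond the scatter, in either direction. The expected step in this assay is a step that the limit leaves unreadable from compound 3 to compound 4. For compound 4 the estimate in this assay is 30000 nM, with a range from 15000 nM to 80000 nM, and it is expected that only a limit will again be reported.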

Compound 4, half-maximal cytotoxic concentration: > 20000 nM
Compound 4 was reported as a limit (the forecaster's own chance of this, stated with the estimate: 85%); the middle value is on the limit's open side.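

Compound 4 gives > 20000 nM in this assay and this is a limit of the assay, so its steps from compound 1, compound 2 and compound 3 cannot be read. The compounds shown leave open whether the groups at this carbon differ at all in cytotoxicity, with every value at one limit: the limit of > 20000 nM in this assay, at which 4 of the 4 values shown sit.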